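The source may report more compounds than this note shows. Statements on the series, on what has been measured and on what is new or still open speak of the compounds shown alone.

Compound 1, `Cc1cccc(Cn2c(CN3CCN(C(=O)c4ccc(C(C)C)cc4)CC3)nc3ccccc32)c1`, gives 67.6% in an assay on isolated protein for inhibition of aldehyde dehydrogenase 1A1 (Homo sapiens), read by spectrophotometry, tested at 10 uM; on this read-out lower numbers stand for less inhibition and higher numbers for more inhibition at the one concentration tested (going by the name of the read-out).
Compound 2, `CCC(=O)N1CCN(Cc2nc3ccccc3n2Cc2cccc(C)c2)CC1`, gives 85.1% in this assay.

Among the measured compounds shown here, compound 2 stands highest of the two numbers; the only measured step, a change of the group on a carbonyl carbon, gave a number 17.5 percentage points higher from compound 1 to compound 2 (beyond the scatter). Compound 3, `Cc1cccc(Cn2c(CN3CCN(C(=O)C4CCCCC4)CC3)nc3ccccc32)c1`, is not yet measured and differs from compound 2 by cyclohexyl in place of ethyl on a carbonyl carbon. That single step is the only one that bears on it, and it went toward the smaller group. For compound 3 a modest fall in this assay is therefore expected, a number 10.1 percentage points lower from compound 2 to compound 3 (beyond the scatter), to an estimated 75% with a range from 55% to 90%.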

Compound 3, a percentage reported as inhibition, at one concentration (the size of the read-out at that concentration, not a potency): 31.9%
For compound 3 the middle estimate is 43.1 percentage points above the measured one; measured number outside the range, below it.
By their numbers in this assay, from the lowest: compound 3; then compound 1; then compound 2.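

At this position on a carbonyl carbon, the read-out in this assay proves far more sensitive than the earlier step showed: cyclohexyl in place of ethyl gives a number 53.2 percentage points lower from compound 2 to compound 3 (beyond the scatter). Cyclohexyl in place of 4-isopropylphenyl also gives a number 35.7 percentage points lower from compound 1 to compound 3 (beyond the scatter), so two ring-bearing groups at this position stand clearly apart. No evidence at hand explains these differences. The compounds shown leave open whether a phenyl, a cyclopropyl or a longer chain such as butyl at this position would stand nearer to ethyl or to cyclohexyl.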